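A few compounds are considered here, and "the series" means these few. Any claim that something is new, unique, unknown or untested is made for them only; others in the source may bear on it.

Measured so far in a functional assay on CNE-2 cells (Homo sapiens) for antiproliferative activity, read by sulforhodamine B assay, with a stated time of 48 h (on this read-out lower numbers stand for stronger inhibition and higher numbers for weaker inhibition), with these results
- compound 1 `COc1ccc(/C=C/C(=O)C(=Cc2ccc(O)c(OC)c2)C(=O)/C=C/c2ccc(OC)cc2OC)c(OC)c1` gives 970 nM
- compound 2 `COc1ccc(/C=C/C(=O)C(=Cc2cc(Br)c(O)c(OC)c2)C(=O)/C=C/c2ccc(OC)cc2OC)c(OC)c1` gives 1780 nM
- compound 3 `COc1ccc(/C=C/C(=O)C(=Cc2cc(OC)c(O)c(OC)c2)C(=O)/C=C/c2ccc(OC)cc2OC)c(OC)c1` gives 850 nM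

Compound 3 cannot be separated from compound 1 on these numbers and stands only modestly clear of compound 2. The two steps that show this are a 1.1-fold lower number from compound 1 to compound 3 (0.06 log units; within the scatter) and a 2.1-fold lower number from compound 2 to compound 3 (0.32 log units; beyond the scatter) in that order.

The next structure is compound 4 `COc1ccc(/C=C/C(=O)C(=Cc2ccc(OC)c(O)c2)C(=O)/C=C/c2ccc(OC)cc2OC)c(OC)c1` and the change is 3-hydroxy-4-methoxyphenyl in place of 4-hydroxy-3,5-dimethoxyphenyl on a double-bonded chain carbon bound to a double-bonded chain carbon on a double-bonded chain carbon bound to a double-bonded chain carbon.

The closest measured guide is methoxy in place of hydrogen on an aromatic carbon, with a 1.1-fold lower number from compound 1 to compound 3 (0.06 log units; within the scatter) as its size. Bromo in place of hydrogen on an aromatic carbon is also small, with a 1.8-fold higher number from compound 1 to compound 2 (0.26 log units; within the scatter) as its size. Going by the values given here, no measured compound carries the 3-hydroxy-4-methoxyphenyl group, so that part of the change remains unmeasured.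

No step beyond the scatter is therefore expected in this assay and the estimate is a 1.2-fold higher number from compound 3 to compound 4 (0.07 log units; within the scatter) for now.

Compound 4 is estimated at 1000 nM with an expected range from 420 nM to 2400 nM in this read-out.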

Compound 4, half-maximal inhibitory concentration: 760 nM
Compound 4: middle estimate off by 1.3-fold (0.12 log units), on the high side; the range from low to high includes it.
By their numbers in this assay, from the lowest: compounds 4, 3, 1 and 2 (each within the scatter of the next, the first and the last beyond it).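

In this assay, the 3-hydroxy-4-methoxyphenyl group on a double-bonded chain carbon bound to a double-bonded chain carbon cannot be separated from the 4-hydroxy-3-methoxyphenyl group, with a 1.3-fold lower number from compound 1 to compound 4 (0.11 log units; within the scatter), or from the 4-hydroxy-3,5-dimethoxyphenyl group, with a 1.1-fold lower number from compound 3 to compound 4 (0.05 log units; within the scatter), so different arrangements of hydroxy and methoxy at this position give no step beyond the scatter among these compounds. The 3-bromo-4-hydroxy-5-methoxyphenyl group now has a second modest step beyond the scatter, with a 2.3-fold lower number from compound 2 to compound 4 (0.37 log units; beyond the scatter), although a 1.8-fold higher number from compound 1 to compound 2 (0.26 log units; within the scatter) stays within it. No evidence on the cause of these differences is available.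

Every compound shown keeps a hydroxy group on this aromatic ring, so the outcome with an amine or a carboxylic acid there remains open. From the compounds shown here alone, the rest of the core is the same throughout, so whether these small steps would hold with a longer chain on it is also open.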